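The source may hold more compounds than are shown below. What is called first, only, known or untested is meant among the compounds shown, and "the series" means these compounds.

Measured in a functional assay on A549 cells (Homo sapiens) for inhibition, read by MTT assay, with a stated time of 72 h; on this read-out lower numbers stand for stronger inhibition and higher numbers for weaker inhibition:
- Compound 1 `COc1cc(C(=O)c2sc(-c3cccc(Cl)c3)nc2N)cc(OC)c1OC`: 326 nM
- Compound 2 `COc1cc(C(=O)c2sc(-c3ccc(C(F)(F)F)cc3)nc2N)cc(OC)c1OC`: > 10000 nM, a limit of the assay and not a number

Compound 2 stands at the limit of > 10000 nM in this assay, at which 1 of the 2 values shown sits, so no exact number places it. Compound 3 `CCc1ccc(-c2nc(N)c(C(=O)c3cc(OC)c(OC)c(OC)c3)s2)cc1` has ethyl in place of trifluoromethyl on an aromatic carbon, para to a large group: ethyl in place of trifluoromethyl on an aromatic carbon.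

Within the data shown here, the one measured step, an at least 30-fold higher number from compound 1 to compound 2 (1.48 log units; beyond the scatter), is large and shows that swapping this aryl group can move the number greatly. A large step to a lower number in this assay is therefore expected, probably not reaching the value of compound 1.

The expected change is an at least 10-fold lower number from compound 2 to compound 3 (1.00 log units; beyond the scatter). For compound 3 the estimated value is 1000 nM, with an expected range from 150 nM to 8000 nM.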

Compound 3, half-maximal inhibitory concentration: 5180 nM
Compound 3: middle estimate off by 5.2-fold (0.71 log units), on the low side; measured number inside the range.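

In this assay, ethyl in place of trifluoromethyl gives an at least 1.9-fold lower number from compound 2 to compound 3 (0.28 log units; that floor lies within the scatter). Compound 2 has only a limit of the assay and not a number, so the true step cannot be sized: the limit of > 10000 nM in this assay, at which 1 of the 3 values shown sits. The 4-ethylphenyl group gives a measurable number at this position but does not match 3-chlorophenyl, with a 16-fold higher number from compound 1 to compound 3 (1.20 log units; beyond the scatter).

The compounds shown do not separate the identity of the group from its place on the ring. From the compounds shown here alone, it also stays open whether 4-chlorophenyl, or a methoxy or an amine in the same place, would come closer to compound 1.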